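Swapping a Chloro for a Methyl on the Phenyl Ring

The compounds below may be only part of what the source reports. "The series", "measured", "known", "first", "only" and "open" are said of these compounds alone.

Measured compounds:
- compound 1, `Clc1ccc(/C=N/Nc2nc(-c3ccccc3)cs2)c(Cl)c1`, 78.1%
- compound 2, `Fc1ccc(-c2csc(N/N=C/c3ccc(Cl)cc3Cl)n2)cc1`, 88.4%
- compound 3, `Clc1ccc(-c2csc(N/N=C/c3ccc(Cl)cc3Cl)n2)cc1`, 76%

In a functional assay, read by spectrophotometry, with a stated time of 15 min, tested at 20 ug/mL (on this read-out higher numbers stand for a stronger effect at the one concentration tested and lower numbers for a weaker effect), compound 3 gives the lowest of the three numbers. Its nearest neighbour is compound 1, since the step of a number 2.1 percentage points lower from compound 1 to compound 3 (within the scatter) stays within the usual scatter, so the two cannot be ranked. Compound 2 stands furthest from it: the step of a number 12.4 percentage points lower from compound 2 to compound 3 (beyond the scatter) lies beyond the scatter, as does the step of a number 10.3 percentage points higher from compound 1 to compound 2 (beyond the scatter).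

Compound 4, `Cc1ccc(-c2csc(N/N=C/c3ccc(Cl)cc3Cl)n2)cc1`, differs from compound 3 in one place: methyl in place of chloro on an aromatic carbon. Among the measured compounds shown here, no measured pair shows methyl in place of chloro on an aromatic carbon, so no step bears on it directly. The steps that exist all concern this same position on the ring, and they show that changing the group there moved the read-out only modestly, with the hydrogen and chloro versions sitting within the scatter of each other and only the fluoro version standing apart. On that basis a change of little size is expected for compound 4, with no confident direction, so the estimated step of a number 2 percentage points higher from compound 3 to compound 4 (within the scatter) is taken as small. Compound 4 is therefore expected to give about 78%, with a plausible range from 64% to 90%.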

Compound 4, a percentage reported as inhibition, at one concentration (the size of the read-out at that concentration, not a potency): 76.2%
The estimate for compound 4 lay 1.8 percentage points above the measured number; the range from low to high includes it.
By their numbers in this assay, from the lowest: compounds 3, 4 and 1 (each within the scatter of the next); then compound 2.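

With a number 0.2 percentage points higher from compound 3 to compound 4 (within the scatter) and a number 1.9 percentage points lower from compound 1 to compound 4 (within the scatter), methyl now joins chloro and hydrogen as a third group that cannot be ranked against the others in this assay, at this place on a six-membered aromatic ring of carbon only, para to a large group. The fluoro version keeps its separate standing against this new group too, with a number 12.2 percentage points lower from compound 2 to compound 4 (beyond the scatter), so among the four groups compared here, fluoro is the only one that stands apart, while swapping chloro for methyl leaves no readable difference. Nothing measured on these compounds offers a reason for the fluoro result or for the closeness of the other three.

The compounds shown leave open how the read-out would respond at this place to a group of another kind, such as an amine, a carboxylic acid or a longer chain like butyl. They also leave open whether compounds that look alike at the single concentration tested would stay alike across a range of concentrations, since such a read-out gives the size of an effect and not a potency.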